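This account rests on a few compounds, and the source may have more. Where it says the series, first, only, none or still open, it means among the compounds named here.

Working notes on the series.

Going by the values given here, compound 2 `C/C1=C/C(=O)CC2=C[C@@H](OC2=O)[C@@H](C(C)C)CC(=O)/C(C)=C/CC1` stands at the lower of the two numbers so far: in a functional assay on HeLa cells (Homo sapiens) for cytotoxicity, read by MTT assay, tested at 10 ug/mL (a lower number here means less inhibition, a higher number more inhibition at the concentration tested (going by the name of the read-out)), compound 2 gives 5.88%, while compound 1 `C/C1=C/CC/C(C)=C/C(=O)CC2=C[C@@H](OC2=O)[C@@H](C(C)C)CC1=O` gives 22.3%. Among the compounds with values here, the one step measured, a number 16.4 percentage points lower from compound 1 to compound 2 (beyond the scatter), rests on the fact that compounds 1 and 2 differ only in the configuration as drawn: the two compounds have the same atoms and bonds and differ only in configuration as drawn, with two double bonds swapped between E and Z.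

Compound 3 `C/C1=C\C(=O)CC2=C[C@@H](OC2=O)[C@@H](C(C)C)CC(=O)/C(C)=C/CC1` is not yet measured. It differs from compound 2 as follows: the two compounds have the same atoms and bonds and differ only in configuration as drawn: 1 of 4 stereo elements differ; a double bond is drawn Z in compound 2 and E in compound 3. Within the data shown here, the relevant evidence is the single measured step, in which a change of two stereo elements lowered the read-out by a modest amount beyond the scatter. Reversing one double bond back from Z to E is a change of the same kind but touching fewer stereo elements, so a step upward from compound 2 is expected, probably smaller than the measured one and possibly within the scatter.

For compound 3 in this assay the expected value is 13%, within 3% to 28%, which corresponds to an expected step of a number 7.1 percentage points higher from compound 2 to compound 3 (within the scatter).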

Compound 3, a percentage reported as inhibition, at one concentration (the size of the read-out at that concentration, not a potency): 1.65%
Compound 3: the middle estimate sits 11.4 percentage points above what was measured, and the stated range ends above it.
By their numbers in this assay, from the lowest: compounds 3 and 2 (each within the scatter of the next); then compound 1.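

The two double bonds that changed together in the earlier step can now be read one at a time. In this assay, reversing one of them alone gives a number 4.2 percentage points lower from compound 2 to compound 3 (within the scatter), whereas reversing the other alone gives a number 20.7 percentage points lower from compound 1 to compound 3 (beyond the scatter). Of these two single changes, only the second lies beyond the scatter, so within this set the larger drop goes with that double bond, and the structures differ in nothing else: the fact that compounds 1 and 3 differ only in the configuration as drawn.

The compounds shown share the same atoms and bonds and the same configuration at their two remaining stereo elements, and whether those elements bear on the read-out remains open, as does whether the pattern at the two double bonds would hold beyond these three compounds. Also open, going by these compounds, is how the read-out, which is a single-concentration inhibition figure and not a potency, would respond to a change in the atoms themselves, such as an amine, a carboxylic acid or a longer chain on the shared core.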